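An Ester of Pyridine Enters Where Carboxy Stood

A few compounds are considered here, and "the series" means these few. Any claim that something is new, unique, unknown or untested is made for them only; others in the source may bear on it.

Compound 3 `Cc1nc2c(OCc3ccccc3)cccn2c1CC(=O)O` sits second of three in a functional assay on the whole organism (stomach) for inhibition, with Canis familiaris (Canis lupus familiaris) as the target, at a dose of 5 mg/kg by the intravenous route; a higher number here means a stronger effect of the compound at the dose given, a lower number a weaker effect: compound 3 gives 24%, compound 1 `COCc1c(C)nc2c(OCc3ccccc3)cccn12` gives 29% and compound 2 `CSCc1c(C)nc2c(OCc3ccccc3)cccn12` gives 8%. The gap a number 5 percentage points lower from compound 1 to compound 3 (within the scatter) and the gap a number 16 percentage points higher from compound 2 to compound 3 (beyond the scatter) show how far this position has moved so far, while the step of a number 21 percentage points lower from compound 1 to compound 2 (beyond the scatter) is the widest swing seen. Compound 4 `Cc1nc2c(OCc3ccccc3)cccn2c1COC(=O)c1cccnc1` differs from compound 3 as follows (((pyridin-3-yl)carbonyl)oxy in place of carboxy on a saturated chain carbon bound to an aromatic carbon). Within the data shown here, no earlier step replaces a group at this place with one of that kind, so the record only shows that changes here have shifted the read-out by modest amounts at most. The expected step is therefore a number 1 percentage points higher from compound 3 to compound 4 (within the scatter), with no clear direction. The estimate for compound 4 is 25%, with a range from 5% to 45%.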

Compound 4, a percentage reported as inhibition, in the whole organism at one dose (the size of the read-out at that dose, not a potency): 88%
For compound 4 the middle estimate is 63 percentage points below the measured one; the whole stated range lies below it.
By their numbers in this assay, from the lowest: compound 2; then compounds 3 and 1 (each within the scatter of the next); then compound 4.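

In this assay, among these compounds, this position proves far more sensitive than the earlier compounds suggested: ((pyridin-3-yl)carbonyl)oxy in place of carboxy gives a large step (a number 64 percentage points higher from compound 3 to compound 4 (beyond the scatter)). The same group also clears the other two neighbours at this place by large steps (a number 80 percentage points higher from compound 2 to compound 4 (beyond the scatter); a number 59 percentage points higher from compound 1 to compound 4 (beyond the scatter)), whereas the earlier changes here were modest at most. No available evidence accounts for this rise.

On these data alone, it remains open whether the gain rests on the pyridine ring or on the ester link. A benzoyl ester, an acetyl ester or the matching amide would separate the two.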